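Nitrate ester series: removing chloro at the aryl ring

The source may hold more compounds than are shown below. What is called first, only, known or untested is meant among the compounds shown, and "the series" means these compounds.

Three compounds of the series have been run in a functional assay on aorta (Rattus norvegicus, strain Wistar) for inhibition; on this read-out lower numbers stand for an effect already at smaller amounts and higher numbers for an effect only at larger amounts of compound. Compound 1 `O=C(CO[N+](=O)[O-])NNC(=O)c1ccc(-n2[nH]c(=O)cc2-c2ccccc2)cc1` gives 26.7 ug/mL. Compound 2 `CCOC(=O)c1c(-c2ccccc2O)n(-c2ccc(C(=O)NNC(=O)CO[N+](=O)[O-])cc2)[nH]c1=O` gives 70.8 ug/mL, and compound 3 `CCOC(=O)c1c(-c2ccc(Cl)cc2)n(-c2ccc(C(=O)NNC(=O)CO[N+](=O)[O-])cc2)[nH]c1=O` gives 50.2 ug/mL. Compound 3 thus stands second highest of the three numbers; its nearest neighbour is compound 2, its furthest compound 1, and both gaps lie within the scatter, so no order among the three can be stated.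

The next step leads to compound 4 `CCOC(=O)c1c(-c2ccccc2)n(-c2ccc(C(=O)NNC(=O)CO[N+](=O)[O-])cc2)[nH]c1=O`, which differs from compound 3 in one place: hydrogen in place of chloro on an aromatic carbon, on an aromatic carbon of a six-membered aromatic ring of carbon only, para to a large group. Within the data shown here, only one measured step touches the same ring: a 1.4-fold lower number from compound 2 to compound 3 (0.15 log units; within the scatter), and that step lay within the scatter. A change at this ring has so far not moved the read-out beyond the usual spread, and compound 1, which also carries a plain phenyl but differs elsewhere, sits within the scatter of compound 3 as well.

Compound 4 is therefore expected to show a 1.1-fold lower number from compound 3 to compound 4 (0.05 log units; within the scatter), that is, no step beyond the scatter in this assay. The estimate for compound 4 is 45 ug/mL, with a range from 22 ug/mL to 90 ug/mL.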

Compound 4, half-maximal effective concentration: 35.5 ug/mL
Estimate against measurement, compound 4: 1.3-fold (0.10 log units) above; the measured number falls inside the stated range.
By their numbers in this assay, from the lowest: compounds 1, 4, 3 and 2 (each within the scatter of the next, the first and the last beyond it).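

In this assay, hydrogen in place of chloro on an aromatic carbon, para to a large group, gives a 1.4-fold lower number from compound 3 to compound 4 (0.15 log units; within the scatter) and so adds a direct read on the 4-chlorophenyl to phenyl change, with no separation from the scatter. The plain phenyl also allows a one-place comparison with the 2-hydroxyphenyl compound: hydrogen in place of hydroxy gives a 2.0-fold lower number from compound 2 to compound 4 (0.30 log units; within the scatter) and so leaves neither chloro nor hydroxy on this ring distinguished from hydrogen in this assay. The same compound gives the first one-place read on the ester, where ethoxycarbonyl in place of hydrogen on an aromatic carbon gives a 1.3-fold higher number from compound 1 to compound 4 (0.12 log units; within the scatter) and thus shows no separation at that carbon either.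

No measurement among the data available accounts for any of these steps. Still open, going by these compounds, is whether an amine, a carboxylic acid or a longer chain on this ring, or a carboxylic acid in place of the ethoxycarbonyl, would give a step beyond the scatter in this assay and thereby show that either position can influence the read-out at all.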